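From carboxylic acid to butyl amide

The source may hold more compounds than are shown below. What is called first, only, known or untested is meant among the compounds shown, and "the series" means these compounds.

Values measured in a functional assay (brain) for inhibition, with Rattus norvegicus as the target (a higher number here means a weaker inhibitor, a lower number a stronger inhibitor), are as follows.
- compound 1 `CCCNC(=O)C1CCc2cc(O)c(OC)cc2O1` gives 119000 nM
- compound 2 `COc1cc2c(cc1O)C(=O)CC(C(=O)O)O2` gives > 300000 nM as a limit

For compound 2 the entry > 300000 nM is a limit of this assay and not a number, so its position is known only as a limit.

Compound 3 `CCCCNC(=O)C1CC(=O)c2cc(O)c(OC)cc2O1` follows from compound 2 through butylamino in place of hydroxy on a carbonyl carbon with butylamino in place of hydroxy on a carbonyl carbon, which reads as carboxy to butylcarbamoyl.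

Within the data shown here, the only amide with a number is compound 1 with 119000 nM as its value, and this is the sole support for the expectation, although its core differs from that of compound 3.

A modest move towards stronger inhibition is expected, estimated as an at least 3.7-fold lower number from compound 2 to compound 3 (0.57 log units; beyond the scatter) in this series.

For compound 3 the expected value is 80000 nM with an estimated range of 20000 nM to 300000 nM in this assay.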

Compound 3, half-maximal inhibitory concentration: 177000 nM
For compound 3 the middle estimate is 2.2-fold (0.34 log units) below the measured one, and the stated range covers the measured number.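

Compound 2 carries > 300000 nM in this assay as a limit and not a number. On the same core, compound 3, with butylcarbamoyl in place of carboxy on the carbonyl carbon, gives 177000 nM as a measured number, and the change reads as an at least 1.6-fold lower number from compound 2 to compound 3 (0.22 log units; that floor lies within the scatter) in this series. As far as these compounds go, that step is only a floor, and its true size stays unknown because it starts from a limit: the limit of > 300000 nM in this assay, at which 1 of the 3 values shown sits.

From the compounds shown here alone, whether the butyl chain itself matters remains open, since a longer chain such as hexylamino, an unsubstituted amide or a methyl ester on the same carbonyl carbon would be needed to separate the chain from the amide. Compound 1 differs from compound 3 in more than one place, so it cannot settle this.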